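This account rests on a few compounds, and the source may have more. Where it says the series, first, only, none or still open, it means among the compounds named here.

In a functional assay on DU-145 cells (Homo sapiens) for cytotoxicity, read by sulforhodamine B assay, with a stated time of 48 h (a lower number here means a stronger inhibitor, a higher number a weaker inhibitor), compound 1 (`C[C@H]1CC[C@@H]2[C@@H](OC(=O)[C@]23CC(c2ccccc2Br)=NO3)[C@]2(C)C(=O)C=C[C@@]12O`) gives 18000 nM and compound 3 (`C[C@H]1CC[C@@H]2[C@@H](OC(=O)[C@]23CC(c2ccccc2F)=NO3)[C@]2(C)C(=O)C=C[C@@]12O`) gives 24000 nM while compound 2 (`COc1cc(C2=NO[C@]3(C2)C(=O)O[C@@H]2[C@H]3CC[C@H](C)[C@]3(O)C=CC(=O)[C@@]23C)ccc1O`) gives 71000 nM as the weakest of the three. Compound 3 stands level with compound 1 at the low end of these numbers. The gap between them is a 1.3-fold higher number from compound 1 to compound 3 (0.12 log units; within the scatter) for fluoro in place of bromo on an aromatic carbon. Compound 2 stands apart, with a 3.9-fold higher number from compound 1 to compound 2 (0.60 log units; beyond the scatter) on one side and a 3.0-fold lower number from compound 2 to compound 3 (0.47 log units; beyond the scatter) on the other.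

The next change, to compound 4 (`Cc1cccc(C2=NO[C@]3(C2)C(=O)O[C@@H]2[C@H]3CC[C@H](C)[C@]3(O)C=CC(=O)[C@@]23C)c1`), is 3-methylphenyl in place of 2-fluorophenyl on a carbon with a double bond to nitrogen and sits next to the ring nitrogen. Among the compounds with values here, no measured compound carries a methyl group on its phenyl ring, so this step has no direct precedent. Only the 4-hydroxy-3-methoxyphenyl group of compound 2 has moved the number beyond the scatter, and both of those steps were modest. That group does not enter here. The closer comparison is the swap between compound 1 and compound 3, which stayed within the scatter.

The expected step in this assay is a 1.1-fold higher number from compound 3 to compound 4 (0.03 log units; within the scatter) and no move beyond the scatter is expected in either direction. Compound 4 is expected at 26000 nM with an estimated range from 12000 nM to 55000 nM for repeat measurements.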

Compound 4, half-maximal inhibitory concentration: 28000 nM
Estimate against measurement, compound 4: 1.1-fold (0.03 log units) below; low and high end bracket the measured number.
By their numbers in this assay, from the lowest: compounds 1, 3 and 4 (each within the scatter of the next); then compound 2.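

In this assay, the 3-methylphenyl group of compound 4, on the carbon with a double bond to nitrogen, cannot be told apart from either halogen-bearing phenyl group: a 1.2-fold higher number from compound 3 to compound 4 (0.07 log units; within the scatter) and a 1.6-fold higher number from compound 1 to compound 4 (0.19 log units; within the scatter) both lie within the scatter. Before this result, the only comparison within the scatter was a swap of one halogen for another, whereas here a methyl-bearing phenyl group joins 2-bromophenyl and 2-fluorophenyl in one group of three compounds. Compound 2 still stands apart, and a 2.5-fold lower number from compound 2 to compound 4 (0.40 log units; beyond the scatter) is a modest step beyond the scatter, so among these four compounds only the 4-hydroxy-3-methoxyphenyl group separates from the rest; no measured data bear on the reason for this grouping.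

The shown compounds leave open whether the hydroxy group, the methoxy group or the two together set compound 2 apart, as they occur only together here. Also open, on these data alone, is how this position responds to an aminophenyl or carboxyphenyl group, or to a saturated ring or a longer alkyl chain in place of the phenyl ring.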